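Replacing 3,4-difluorophenyl with phenyl on the shared core

A few compounds are considered here, and "the series" means these few. Any claim that something is new, unique, unknown or untested is made for them only; others in the source may bear on it.

Of the compounds shown here, two have so far been measured in a functional assay on NCI-H460 cells (Homo sapiens) for inhibition, with a stated time of 72 h; a higher number here means a weaker inhibitor, a lower number a stronger inhibitor. Compound 1 (`COc1ccc(S(=O)(=O)N2CCc3cccc(-c4ccc(F)c(F)c4)c32)cc1`) gives 46 nM and holds the lower of the two numbers. Its nearest neighbour, compound 2 (`COc1ccc(S(=O)(=O)N2CCc3cccc(-c4cc(OC)c(OC)c(OC)c4)c32)cc1`), gives 6340 nM and lies far higher, well beyond the usual scatter. The next compound to be measured is compound 3 (`COc1ccc(S(=O)(=O)N2CCc3cccc(-c4ccccc4)c32)cc1`). It carries phenyl in place of 3,4-difluorophenyl on an aromatic carbon of the shared core (phenyl in place of 3,4-difluorophenyl on an aromatic carbon). Within the data shown here, no measured pair isolates this change, so any expectation is tentative. Among the measured compounds shown here, the values of compound 1 at 46 nM and compound 2 at 6340 nM show only that the number can differ widely between compounds on this core. A small step is expected here, towards a higher number and a somewhat weaker inhibitor, only a little beyond the scatter. The estimated step is a 2.6-fold higher number from compound 1 to compound 3 (0.42 log units; beyond the scatter) in this assay and remains uncertain in both size and direction. Compound 3 is therefore estimated at 120 nM with an expected range from 35 nM to 450 nM for its measurement.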

Compound 3, half-maximal inhibitory concentration: 213 nM
Compound 3: middle estimate off by 1.8-fold (0.25 log units), on the low side; measured number inside the range.
By their numbers in this assay, from the lowest: compound 1; then compound 3; then compound 2.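

In this assay, among these compounds, the pair gives the first direct reading at this position on the shared core: replacing 3,4-difluorophenyl with phenyl brings a 4.6-fold higher number from compound 1 to compound 3 (0.67 log units; beyond the scatter) as a modest step, so the two fluorine atoms are linked to a lower number, while their removal does not cost all of the activity. Compound 3 at 213 nM still lies well under compound 2 at 6340 nM in this assay, so the bare phenyl already gives a much lower number than the group carried by compound 2 at the same place. No measurement at hand accounts for the step between the two fluorinated and unfluorinated compounds.

The compounds shown leave open whether a single fluorine on the phenyl would hold the number of compound 1 or give that of compound 3, since the pair removes both fluorine atoms at once. They also leave open how other groups on this phenyl would read, such as chlorine, a nitrile or an amine, and whether a pyridine ring could take its place.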